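The source may report more compounds than this note shows. Statements on the series, on what has been measured and on what is new or still open speak of the compounds shown alone.

Three compounds have been measured in an assay on isolated protein for inhibition of ubiquitin carboxyl-terminal hydrolase 7 (Homo sapiens), with stated times of 30 min and 2 h; on this read-out higher numbers stand for weaker inhibition and lower numbers for stronger inhibition:

Compound 1 `CC(C)NCc1ccc(-c2c3ncn(CC4(O)CCN(Cc5ccc(-c6ccco6)cc5Cl)CC4)c(=O)c3nn2C)cc1` gives 29.1 nM.
Compound 2 `Cn1nc2c(=O)n(CC3(O)CCN(Cc4ccc(-c5ccncc5)cc4Cl)CC3)cnc2c1-c1ccc(CN)cc1` gives 257 nM.
Compound 3 `Cn1nc2c(=O)n(CC3(O)CCN(Cc4ccc(-c5ccco5)cc4Cl)CC3)cnc2c1-c1ccc(Cl)cc1` gives 143 nM.

Compound 2 has the highest of the three numbers, which on this read-out means the weakest inhibition. Against compound 3 the difference is within the usual scatter, so the two cannot be ranked; against compound 1 it is clearly beyond the scatter.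

Compound 4 `Cn1nc2c(=O)n(CC3(O)CCN(Cc4ccc(-c5ccc(C(=O)O)o5)cc4Cl)CC3)cnc2c1-c1ccc(CN)cc1` differs from compound 2 in one place: 5-carboxyfuran-2-yl in place of pyridin-4-yl on an aromatic carbon. The group enters on an aromatic carbon of a six-membered aromatic ring of carbon only, meta to a chloro group and para to a large group.

For the measured compounds named here, only one single-change step has been measured, a 4.9-fold higher number from compound 1 to compound 3 (0.69 log units; beyond the scatter), and it alters the group on the far side of the shared core, not the place changed here. Compounds 1 and 3 do carry a furan at that place, but they differ from compound 2 elsewhere as well, so no clean comparison exists. With nothing that bears directly on this exchange, the expected step of a 1.0-fold lower number from compound 2 to compound 4 (0.01 log units; within the scatter) in this assay is none beyond the scatter, in no particular direction. Compound 4 is therefore estimated at 250 nM, within 90 nM to 700 nM.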

Compound 4, half-maximal inhibitory concentration: 753 nM
The estimate for compound 4 lay 3.0-fold (0.48 log units) below the measured number; the whole stated range lies below it.
By their numbers in this assay, from the lowest: compound 1; then compounds 3 and 2 (each within the scatter of the next); then compound 4.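

In this assay, the aromatic carbon meta to a chloro group and para to a large group proves sensitive to what it carries: 5-carboxyfuran-2-yl in place of pyridin-4-yl gives a 2.9-fold higher number from compound 2 to compound 4 (0.47 log units; beyond the scatter) as a modest loss of inhibition. For the compounds shown here, the earlier compounds could not show this, since the only single-change step among them lay on the far side of the shared core. This one exchange, however, replaces a six-membered aromatic ring with a five-membered one and also brings in a carboxylic acid, and nothing measured here explains the step.

Going by these compounds, what remains open is whether the furan ring or its carboxylic acid accounts for the step, and a plain furan-2-yl on the frame of compound 2 would separate the two. Also open, on these data alone, is how a methyl ester or a primary amide in place of the carboxylic acid would read, and whether the step would be the same with the (isopropylamino)methyl group of compound 1 on the far side.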